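The source may report more compounds than this note shows. Statements on the series, on what has been measured and on what is new or still open speak of the compounds shown alone.

Compound 1 `Nc1ccc(/C=C2\SC(=O)N(Cc3ccc(Cl)cc3)C2=O)cc1` gives 60000 nM in a functional assay on FM3A cells (Mus musculus) for cytotoxicity, read by cell counting, with a stated time of 2 days; on this read-out lower numbers stand for stronger inhibition and higher numbers for weaker inhibition; compound 2 `Nc1ccc(/C=C2\SC(=O)N(Cc3cccc(F)c3)C2=O)cc1` gives 121000 nM; compound 3 `C=C(Br)C(=O)Nc1ccc(/C=C2\SC(=O)N(CC)C2=O)cc1` gives 2300 nM.

Compound 3 stands lowest of the three numbers, and its distance to both other compounds lies beyond the scatter. Compound 4 `CCN1C(=O)S/C(=C\c2ccc(N)cc2)C1=O` differs from compound 3 by hydrogen in place of (1-bromoethenyl)carbonyl on a nitrogen on an aromatic ring. Within the data shown here, the only measured step, a 2.0-fold higher number from compound 1 to compound 2 (0.30 log units; within the scatter), concerns a different place in the molecule and does not bear on this change, so no measured step speaks directly to it. Compounds 1 and 2, which both carry an amino group on the aromatic ring, give far higher numbers than compound 3. Compound 4 is therefore expected to give a higher number as well, a step of a 35-fold higher number from compound 3 to compound 4 (1.54 log units; beyond the scatter). In this assay compound 4 is estimated at 80000 nM, within a range from 15000 nM to 300000 nM.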

Compound 4, half-maximal inhibitory concentration: 76000 nM
Compound 4: middle estimate off by 1.1-fold (0.02 log units), on the high side, and the stated range covers the measured number.
By their numbers in this assay, from the lowest: compound 3; then compounds 1, 4 and 2 (each within the scatter of the next).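

In this assay, hydrogen in place of (1-bromoethenyl)carbonyl on the aromatic amine nitrogen gives a 33-fold higher number from compound 3 to compound 4 (1.52 log units; beyond the scatter), a large change at this position. Among the compounds with the free amino group, methyl in place of the aromatic ring on the chain carbon gives a 1.6-fold lower number from compound 2 to compound 4 (0.20 log units; within the scatter) and a 1.3-fold higher number from compound 1 to compound 4 (0.10 log units; within the scatter), both within the scatter, so that part of the molecule barely registers here. Nothing measured here gives a cause for the large step.

Which part of the (1-bromoethenyl)carbonyl carries the step stays open; an acetyl group on the same nitrogen would help separate the carbonyl from the bromoethenyl part. Also open, from the compounds shown here alone, is whether 4-chlorophenyl or 3-fluorophenyl on the chain carbon would matter with (1-bromoethenyl)carbonyl in place.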